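From compound 1 to compound 4 in the tail flick test

The compounds below may be only part of what the source reports. "The series", "measured", "known", "first", "only" and "open" are said of these compounds alone.

Of the compounds shown here, three sharing one core have been measured in a functional assay on the whole organism (Tail, strain ICR) with Mus musculus as the target, in the tail flick test, with a stated time of 150 min, at a dose of 25 umol/kg by the oral route; on this read-out lower numbers stand for a weaker effect and higher numbers for a stronger effect at the one dose given. Compound 1, `NCCCC[C@H](NC(=O)CN(c1nc(Cl)nc2[nH]cnc12)C1CC1)C(=O)OCc1ccccc1`, gives 9.88%. Compound 2, `O=C(O)CC[C@H](NC(=O)CN(c1nc(Cl)nc2[nH]cnc12)C1CC1)C(=O)O`, gives 29.5%, and compound 3, `CSCC[C@H](NC(=O)CN(c1nc(Cl)nc2[nH]cnc12)C1CC1)C(=O)O`, gives 4.14%. Compound 1 thus stands second highest of the three: its value and that of compound 3 lie within the scatter of each other, while compound 2 sits higher, beyond the scatter. Within the data shown here, the only measured step, an exchange of one side group for another, is a number 25.4 percentage points lower from compound 2 to compound 3 (beyond the scatter). Compound 4, `C[C@@H](O)[C@H](NC(=O)CN(c1nc(Cl)nc2[nH]cnc12)C1CC1)C(=O)OCc1ccccc1`, differs from compound 1 by 1-hydroxyethyl in place of 4-aminobutyl on a saturated chain carbon bound to an amide-type nitrogen and a carbonyl carbon. Among the measured compounds shown here, no measured step matches this exchange, so only a small movement, if any, is expected for compound 4, a number 2.1 percentage points higher from compound 1 to compound 4 (within the scatter). Compound 4 is therefore estimated at 12%, within 0% to 30%.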

Compound 4, a percentage reported as activity, at one dose (the size of the read-out at that dose, not a potency): 12.8%
Beside the measured number, compound 4's estimate is 0.8 percentage points below it, and the stated range covers the measured number.
By their numbers in this assay, from the lowest: compounds 3, 1 and 4 (each within the scatter of the next); then compound 2.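

On the saturated chain carbon bound to an amide-type nitrogen and a carbonyl carbon, 1-hydroxyethyl in place of 4-aminobutyl gives a number 2.9 percentage points higher from compound 1 to compound 4 (within the scatter) in this assay. This position therefore accepts a smaller side group with a hydroxyl instead of an amine and shows no change beyond the usual scatter. Nothing available explains this result. On these data alone, what a phenyl ring or a plain methyl would give at this position remains open. Also open, as far as these compounds go, is whether these two side groups would compare in the same way with a free carboxylic acid replacing the ester.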